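The source may hold more compounds than are shown below. What is called first, only, known or untested is meant among the compounds shown, and "the series" means these compounds.

Measured in a functional assay on A549 cells (Homo sapiens) for inhibition, read by MTT assay, with a stated time of 48 h; on this read-out lower numbers stand for stronger inhibition and higher numbers for weaker inhibition:

compound 1, `O=C(Nc1cnn(-c2ccccc2)c1)c1cccc(NS(=O)(=O)c2ccccc2)c1`: 26800 nM
compound 2, `Cc1ccc(-n2cc(NC(=O)c3cccc(NS(=O)(=O)c4ccccc4)c3)cn2)cc1`: 18900 nM
compound 3, `O=C(Nc1cnn(-c2ccccc2)c1)c1ccc(NS(=O)(=O)c2ccccc2)cc1`: 87100 nM

Compound 1 and compound 2 differ in one place: methyl in place of hydrogen on an aromatic carbon. The step that this change made, a 1.4-fold lower number from compound 1 to compound 2 (0.15 log units; within the scatter), is small, and the two values are best read as alike. Compound 3 is built from the same atoms as compound 1, joined differently; the difference between the two cores is not broken down here. What the values show is that compound 3 gives a higher number than compound 1 and than compound 2, in both cases by more than the usual scatter.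

Compound 4, `Cc1ccc(-n2cc(NC(=O)c3ccc(NS(=O)(=O)c4ccccc4)cc3)cn2)cc1`, stands to compound 3 as compound 2 stands to compound 1: methyl in place of hydrogen on an aromatic carbon. The place of the change is the same in both pairs, so it is the same change. Because the earlier step of a 1.4-fold lower number from compound 1 to compound 2 (0.15 log units; within the scatter) stayed within the scatter, the step from compound 3 to compound 4 is expected to be similar, a 1.4-fold lower number from compound 3 to compound 4 (0.15 log units; within the scatter). Compound 4 is therefore estimated at 62000 nM, with a likely range from 30000 nM to 130000 nM.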

Compound 4, half-maximal inhibitory concentration: 54700 nM
Estimate against measurement, compound 4: 1.1-fold (0.05 log units) above, and the stated range covers the measured number.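

Swapping phenyl for 4-methylphenyl on the second core, in this assay, gives a 1.6-fold lower number from compound 3 to compound 4 (0.20 log units; within the scatter), so here too the methyl group leaves the two values alike. Set beside the earlier step, the same change behaves in the same way on both cores: the same change on two cores in this assay, a 1.4-fold lower number (0.15 log units; within the scatter) from compound 1 to compound 2 and a 1.6-fold lower number (0.20 log units; within the scatter) from compound 3 to compound 4, 1.1-fold (0.05 log units) apart, within the scatter of two such steps

This shows that, for these two pairs, the methyl group can be carried from one core to the other with a matching small result, but it does not show that the methyl group improves inhibition, that the same would hold on any further core, or why the step is so small.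

The compounds shown have only hydrogen or methyl at this place, so it remains open whether a chlorine atom, a methoxy group or an amine there would shift the number beyond the scatter. From the compounds shown here alone, it also remains open whether a longer chain or a carboxylic acid at this place would carry over equally well between the two cores.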